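Chloro in place of bromo: compound 3 to compound 4

The source may report more compounds than this note shows. Statements on the series, on what has been measured and on what is new or still open speak of the compounds shown alone.

Compound 3 (`O=S(=O)(/C=C/c1ccc(Br)cc1)Cc1ccc(Nc2ncnc3ccc(Br)cc23)cc1`) gives > 100000 nM in a functional assay on SW-620 cells (Homo sapiens) (a lower number here means a stronger inhibitor of growth, a higher number a weaker inhibitor of growth), which is a limit of the assay and not a number. Compound 4 (`O=S(=O)(/C=C/c1ccc(Cl)cc1)Cc1ccc(Nc2ncnc3ccc(Br)cc23)cc1`) differs from it by one substitution: chloro in place of bromo on an aromatic carbon.

Within the data shown here, only one measured step touches this ring. Compound 2 (`O=S(=O)(/C=C/c1ccc(Cl)c(Cl)c1)Cc1ccc(Nc2ncnc3ccc(Br)cc23)cc1`) gives 5000 nM in this assay, and an at least 20-fold higher number from compound 2 to compound 3 (1.30 log units; beyond the scatter) is large, with 4-bromophenyl in place of 3,4-dichlorophenyl. That step also removes a chloro, so it does not measure the present swap directly. Compound 1 (`O=S(=O)(/C=C/c1ccc(Cl)cc1)Cc1ccc(Nc2ncnc3ccccc23)cc1`) carries the 4-chlorophenyl of compound 4 on a core without the bromo. Compound 1 gives 77000 nM.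

A modest move towards a lower number is therefore expected, far smaller than the step to compound 2. In this assay, the expected size is an at least 2.0-fold lower number from compound 3 to compound 4 (0.30 log units; that floor lies within the scatter), and this remains loose. For compound 4 the estimate is 50000 nM, with an expected range of 12000 nM to 100000 nM.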

Compound 4, concentration for 50% growth inhibition: 45000 nM
Compound 4: the middle estimate sits 1.1-fold (0.05 log units) above what was measured; the range from low to high includes it.
By their numbers in this assay, from the lowest: compound 2; then compounds 4 and 1 (each within the scatter of the next). At a limit, above all of these: compound 3.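

In this assay, hydrogen in place of chloro on an aromatic carbon (a 9.0-fold higher number from compound 2 to compound 4 (0.95 log units; beyond the scatter)) separates the loss of one chloro of the 3,4-dichlorophenyl from the bromo swap, which the step to compound 3 had mixed together. Bromo in place of hydrogen on an aromatic carbon of the core leaves compound 1 and compound 4 within the scatter of each other (a 1.7-fold lower number from compound 1 to compound 4 (0.23 log units; within the scatter)). Chloro in place of bromo, para to a large group, now has a direct step (an at least 2.2-fold lower number from compound 3 to compound 4 (0.34 log units; beyond the scatter)), but its size is only a bound, since compound 3 stands at a limit: the limit of > 100000 nM in this assay, at which 1 of the 4 values shown sits.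

From the compounds shown here alone, what a methoxy or an amine would give at this position stays open. So does whether the second chloro of the 3,4-dichlorophenyl has a similar effect on the core of compound 1.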